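The source may hold more compounds than are shown below. What is called first, only, known or untested is meant among the compounds shown, and "the series" means these compounds.

The shared core of compound 1 `CCOC(=O)c1cccc(-c2ccc(OCC)cc2)c1` carries an ethoxycarbonyl group, and in an assay on COS-7 cells for inhibition of patatin-like phospholipase domain-containing protein 2 (Mus musculus) (a higher number here means a weaker inhibitor, a lower number a stronger inhibitor), compound 1 gives 50000 nM. Compound 2 `CCOc1ccc(-c2cccc(S(=O)(=O)N(C)C)c2)cc1` replaces that group with dimethylsulfamoyl, and in this assay compound 2 gives 110000 nM, a change of a 2.2-fold higher number from compound 1 to compound 2 (0.34 log units; beyond the scatter). Compound 3 `CCOc1ccc(-c2cccc(C(=O)NC)c2)cc1` carries methylcarbamoyl instead; in this assay compound 3 reaches only the limit of the assay, > 200000 nM, so for compound 3 no number is known, only this limit (the limit of > 200000 nM in this assay, at which 1 of the 3 values shown sits). The step from the ester is an at least 4.0-fold higher number from compound 1 to compound 3 (0.60 log units; beyond the scatter), and the step from the sulfonamide is an at least 1.8-fold higher number from compound 2 to compound 3 (0.25 log units; that floor lies within the scatter).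

Compound 4 `CCOc1ccc(-c2cccc(NC(C)=O)c2)cc1` differs from compound 3 by acetamido in place of methylcarbamoyl on an aromatic carbon. For the measured compounds named here, the steps that bear on this exchange are the swaps of the same group in compound 2 and compound 3, which were modest or within the scatter in this assay; none of them moved a value far, and the group in compound 4 keeps the same count of atoms, donor and acceptor as the one it replaces. The expected change is therefore a step of a number no higher from compound 3 to compound 4 (the limit leaves the size open), with little movement beyond the scatter in either direction. Compound 4 is expected to give about 200000 nM in this assay, with a range from 80000 nM to 500000 nM, and a value reported only as a limit remains likely.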

Compound 4, half-maximal inhibitory concentration: 200000 nM
Compound 4: middle estimate and measured number agree at the digits printed, and the stated range covers the measured number.
By their numbers in this assay, from the lowest: compound 1; then compounds 2 and 4 (each within the scatter of the next).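

Compound 4 has the same atoms as compound 3, joined differently, and unlike compound 3 it gives a readable number in this assay. Acetamido in place of methylcarbamoyl gives a number no higher from compound 3 to compound 4 (the limit leaves the size open). Against the sulfonamide, the acetamido group shows a 1.8-fold higher number from compound 2 to compound 4 (0.26 log units; within the scatter), so these two groups cannot be told apart here, while against the ester it shows a 4.0-fold higher number from compound 1 to compound 4 (0.60 log units; beyond the scatter), which places a second group, alongside the dimethylsulfamoyl of compound 2, measurably on the weaker side of the ethoxycarbonyl of compound 1. The step between the two amide arrangements cannot be read, because compound 3 stands only at a limit: the limit of > 200000 nM in this assay, at which 1 of the 4 values shown sits.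

Of the groups shown on this aromatic carbon, only the ester of compound 1 stands apart from the others, and whether that reflects something particular to the ester remains open, since a carboxylic acid or a longer ester chain does not appear among these compounds. Also open, going by these compounds, is whether any group here could bring the number far below that of compound 1 while the ethoxy group on the shared core stays in place, or whether an amine or a longer ether chain in place of that ethoxy group would matter more.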